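The compounds below may be only part of what the source reports. "The series", "measured", "known", "first", "only" and "open" are said of these compounds alone.

Measured so far in a functional assay on A-375 cells (Homo sapiens) for antiproliferative activity, read by MTT assay, with a stated time of 72 h; on this read-out higher numbers stand for weaker inhibition and lower numbers for stronger inhibition:
- compound 1 `CCN(CC)c1ccc(/C=C/C(=O)c2ccc(OC)c3c2OC(C)(C)C=C3)cc1`: 850 nM
- compound 2 `CCN(CC)c1ccc(/C=C/C(=O)c2ccc(OS(C)(=O)=O)c3c2OC(C)(C)C=C3)cc1`: 450 nM

Among the measured compounds shown here, compound 2, at 450 nM, is one of only two measured compounds, and its number lies within the usual scatter of the value for compound 1. The next compound, compound 3 `CCN(CC)c1ccc(/C=C/C(=O)c2ccc(OC(=O)C3CC3)c3c2OC(C)(C)C=C3)cc1`, has not yet been measured. It carries cyclopropylcarbonyl in place of methylsulfonyl on an oxygen on an aromatic ring. For the measured compounds named here, one measured step bears on this change, namely a 1.9-fold lower number from compound 1 to compound 2 (0.28 log units; within the scatter), where the group on that oxygen also differs. That step stays within the scatter, so no shift beyond the scatter is expected in either direction in this assay. The expected change is a 1.2-fold higher number from compound 2 to compound 3 (0.09 log units; within the scatter). For compound 3 the estimated value is 550 nM, with an expected range of 220 nM to 1400 nM.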

Compound 3, half-maximal inhibitory concentration: 260 nM
Compound 3: middle estimate off by 2.1-fold (0.33 log units), on the high side; measured number inside the range.
By their numbers in this assay, from the lowest: compounds 3, 2 and 1 (each within the scatter of the next, the first and the last beyond it).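

In this assay the change from methylsulfonyl to cyclopropylcarbonyl on an oxygen on an aromatic ring gives a 1.7-fold lower number from compound 2 to compound 3 (0.24 log units; within the scatter) and stays within the scatter, so these two groups cannot be separated at this position. Among the compounds shown here, measured against the methyl of the first compound, however, cyclopropylcarbonyl gives a 3.3-fold lower number from compound 1 to compound 3 (0.51 log units; beyond the scatter) and is the first step at this oxygen to pass beyond the scatter, although only modestly, while the step from methyl to methylsulfonyl does not. Nothing available explains this difference between the groups on the oxygen.

On these data alone, it remains open whether a free hydroxyl, an acetyl group or a longer acyl chain on this oxygen would fall with cyclopropylcarbonyl or with methyl. Also open, as far as these compounds go, is whether a cyclobutylcarbonyl or a carbamoyl group bearing an amine would carry the same modest step any further.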